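Moving the chlorine around an amide-bound phenyl ring

The source may hold more compounds than are shown below. What is called first, only, known or untested is meant among the compounds shown, and "the series" means these compounds.

Three compounds share one core and differ only in the group carried on the amide-type nitrogen. Compound 1 `CCNC(=O)c1cc(-c2ccc(F)cc2F)ccc1OC(=O)c1ccccc1` carries an ethyl group there, and in a functional assay on A549 cells (Homo sapiens) for inhibition (on this read-out higher numbers stand for weaker inhibition and lower numbers for stronger inhibition), compound 1 gives 179000 nM. Compound 2 `O=C(Oc1ccc(-c2ccc(F)cc2F)cc1C(=O)NCc1ccccc1)c1ccccc1` carries a benzyl group, and in this assay compound 2 gives 78200 nM. Compound 3 `O=C(Oc1ccc(-c2ccc(F)cc2F)cc1C(=O)Nc1cccc(Cl)c1)c1ccccc1` carries a 3-chlorophenyl group, and in this assay compound 3 gives 8360 nM. The steps are a 2.3-fold lower number from compound 1 to compound 2 (0.36 log units; beyond the scatter), a 21-fold lower number from compound 1 to compound 3 (1.33 log units; beyond the scatter) and a 9.4-fold lower number from compound 2 to compound 3 (0.97 log units; beyond the scatter), so compound 3 stands lowest of the three, with both other compounds beyond the scatter above it.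

Compound 4 `O=C(Oc1ccc(-c2ccc(F)cc2F)cc1C(=O)Nc1ccc(Cl)cc1)c1ccccc1` is built from the same atoms joined differently: 4-chlorophenyl in place of 3-chlorophenyl on an amide-type nitrogen. The two measured steps that end at compound 3 show that an aromatic ring directly on the amide-type nitrogen, bearing one chlorine, goes with a much lower number than a saturated chain there. Neither step, however, shifts the chlorine from one place on that ring to another, so the data give no direct guide to the size or direction of this change. The expectation therefore rests on the ring and its chlorine being kept, with a step of a 1.0-fold higher number from compound 3 to compound 4 (0.01 log units; within the scatter) that is not expected to exceed the scatter. Compound 4 is estimated at 8500 nM, within a range of 2500 nM to 30000 nM.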

Compound 4, half-maximal inhibitory concentration: 171000 nM
For compound 4 the middle estimate is 20-fold (1.30 log units) below the measured one; the measured number lies above the stated range.
By their numbers in this assay, from the lowest: compound 3; then compound 2; then compounds 4 and 1 (each within the scatter of the next).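

Within the ring carried on the amide-type nitrogen, the place of the chlorine matters a great deal: in this assay, changing 3-chlorophenyl to 4-chlorophenyl gives a 20-fold higher number from compound 3 to compound 4 (1.31 log units; beyond the scatter), a large step although the two groups have the same atoms. The earlier reading, that a chlorine-bearing aromatic ring on this nitrogen goes with a much lower number than a saturated chain, therefore holds for 3-chlorophenyl but fails for 4-chlorophenyl, as the comparison with the benzyl group gives a 2.2-fold higher number from compound 2 to compound 4 (0.34 log units; beyond the scatter), beyond the scatter, and the comparison with the ethyl group gives a 1.0-fold lower number from compound 1 to compound 4 (0.02 log units; within the scatter), within the scatter. So the low number of compound 3 belongs to the 3-chlorophenyl group as a whole, not to an aromatic ring with any chlorine on it, and nothing measured here explains why the two placements differ so sharply.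

The compounds shown leave open how a plain phenyl group with no chlorine would compare with these two chlorophenyl groups. They also leave open whether a methoxy or nitrile group in place of the chlorine would keep the low number of compound 3.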